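A few compounds are considered here, and "the series" means these few. Any claim that something is new, unique, unknown or untested is made for them only; others in the source may bear on it.

Working notes on the series. In an assay on HEK-293T cells for inhibition of diacylglycerol lipase-alpha (Homo sapiens), read by colorimetric assay (on this read-out lower numbers stand for stronger inhibition and higher numbers for weaker inhibition), compound 1 `CCC1CCCCN1C(=O)n1ncc(C(O)(c2ccccc2)c2ccccc2)n1` gives 63.1 nM, the higher of the two numbers in hand; compound 2 `COc1cccc(CC2CCCCN2C(=O)n2ncc(C(O)(c3ccc(F)cc3)c3ccc(F)cc3)n2)c1` gives 3.16 nM, a gap beyond the scatter. Going by the values given here, no step between measured compounds differing in one place is available. Compound 3 `O=C(N1CCCCC1COc1ccccc1)n1ncc(C(O)(c2ccccc2)c2ccccc2)n1` carries phenoxy in place of methyl on a saturated chain carbon bound to a saturated ring carbon. Compound 2 also bears an aromatic group on a saturated chain carbon bound to a saturated ring carbon, among other changes, and shows the lower number, so a move toward lower numbers beyond the scatter is expected for compound 3, short of the full gap. Compound 3 is expected to give 16 nM, between 4 nM and 60 nM. That amounts to an expected step of a 3.9-fold lower number from compound 1 to compound 3 (0.60 log units; beyond the scatter).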

Compound 3, half-maximal inhibitory concentration: 7.94 nM
The estimate for compound 3 lay 2.0-fold (0.30 log units) above the measured number; low and high end bracket the measured number.
By their numbers in this assay, from the lowest: compound 2; then compound 3; then compound 1.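

In this assay, going by these compounds alone, phenoxy in place of methyl on a saturated chain carbon bound to a saturated ring carbon gives a 7.9-fold lower number from compound 1 to compound 3 (0.90 log units; beyond the scatter) in the only single-place comparison available. This place therefore accepts a group with one six-membered aromatic ring and one hydrogen-bond acceptor, with stronger inhibition rather than a loss. Nothing measured on these compounds offers an explanation for this step.

As far as these compounds go, whether the step goes with the aromatic ring or with the oxygen stays open. A cyclohexyloxy or benzyl group at this place would separate the two.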